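Methyl to Hydrogen on the Ring Carbon Between Two Oxygens

The source may hold more compounds than are shown below. What is called first, only, known or untested is meant among the compounds shown, and "the series" means these compounds.

Compound 1 `C[C@]1(c2ccccc2)OCC[C@H](CCN)O1`: > 10000 nM
Compound 2 `C[C@@]1(c2ccccc2)OCC[C@@H](CCN)O1`: > 10000 nM

In an assay on brain for displacement of a labelled ligand from Sigma non-opioid intracellular receptor 1 (Cavia porcellus) (a lower number here means a stronger inhibitor, a higher number a weaker inhibitor), compound 1 gives > 10000 nM, which is a limit of the assay and not a number. In this assay compound 2 gives > 10000 nM, again a limit. The step that the two limits leave unreadable from compound 1 to compound 2 cannot be read, because of the limit of > 10000 nM in this assay, at which 2 of the 2 values shown sit. Compound 3 `NCC[C@@H]1CCO[C@H](c2ccccc2)O1` differs from compound 2 by hydrogen in place of methyl on a saturated ring carbon. For the measured compounds named here, no measured step bears on this change, and the two limits give no scale for it. Compound 3 is therefore estimated at 15000 nM, within 3000 nM to 60000 nM. The expected step that the limit leaves unreadable from compound 2 to compound 3 is a guess, with another limit the likeliest outcome.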

Compound 3, inhibition constant: > 10000 nM
Compound 3 ended at the assay's limit; the forecaster's own chance of this, stated with the estimate: 70%; the middle value is on the limit's open side.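

In this assay compound 3 gives > 10000 nM, again a limit of the assay, so the step from compound 2 to compound 3 cannot be read: the limit of > 10000 nM in this assay, at which 3 of the 3 values shown sit.

The compounds shown leave open whether hydrogen in place of methyl, or the inverted configuration, changes the inhibition constant at all.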